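The compounds below may be only part of what the source reports. "The series", "measured", "known", "first", "only" and "open" are said of these compounds alone.

In a functional assay on HL-60 cells (Homo sapiens) for antiproliferative activity, read by MTT assay, with a stated time of 48 h (a higher number here means a weaker inhibitor, a lower number a stronger inhibitor), compound 1 `CCN(CC)CCCn1c(N)c(-c2nc3ccccc3[nH]2)c2nc(C#N)c(C#N)nc21` gives > 730 nM. That value is a limit of the assay and not a number.

Within the data shown here, compound 2 `CN(C)CCCn1c(N)c(-c2nc3ccccc3n2C)c2nc(C#N)c(C#N)nc21` gives 2120 nM, and this is the only true number available so far. With just one number and one limit, compound 2 cannot yet be ranked against anything. Compound 1 also differs from it in more than one place, so the two values say little about any single structural change.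

The next compound, compound 3 `CCN(CC)CCCn1c(N)c(-c2nc3ccccc3n2C)c2nc(C#N)c(C#N)nc21`, keeps the core of compound 2 and changes only the amine at the end of the side chain: diethylamino in place of dimethylamino on a saturated chain carbon, three bonds along the chain from an aromatic nitrogen. Diethylamino stands in place of dimethylamino on a saturated chain carbon, three bonds along the chain from an aromatic nitrogen, so a 3-(dimethylamino)propyl group becomes a 3-(diethylamino)propyl group.

Among the measured compounds shown here, no measured pair shows this change alone. With compound 2 at 2120 nM as the only anchor, no shift beyond the usual scatter is expected in this assay. The expected step, a 1.2-fold lower number from compound 2 to compound 3 (0.07 log units; within the scatter), is therefore small. For compound 3 the estimated value is 1800 nM, with an expected range of 700 nM to 4500 nM.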

Compound 3, half-maximal inhibitory concentration: 2810 nM
Compound 3: the middle estimate sits 1.6-fold (0.19 log units) below what was measured; the range from low to high includes it.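

In this assay, among these compounds, diethylamino in place of dimethylamino at the end of the side chain gives a 1.3-fold higher number from compound 2 to compound 3 (0.12 log units; within the scatter), and this is the first pair that shows this change alone. At this place, on a saturated chain carbon, three bonds along the chain from an aromatic nitrogen, going from 3 heavy atoms to 5 in the amine therefore leaves compound 2 and compound 3 indistinguishable in this read-out. Compound 1 gives only a limit and not a number, so the step for methyl in place of hydrogen on an aromatic nitrogen cannot be read: the limit of > 730 nM in this assay, at which 1 of the 3 values shown sits.

From the compounds shown here alone, the role of that methyl group thus stays open, since a true number for a compound with hydrogen on that aromatic nitrogen would be needed to size it. Also open, going by these compounds, is whether a larger change at the end of the side chain, such as a ring amine like morpholine or piperidine, or a longer chain leading to the amine, would move the value beyond the usual scatter of repeated measurements.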